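Swapping an Ester for a Nitrile on a Weak Cytotoxic Diterpenoid

This account rests on a few compounds, and the source may have more. Where it says the series, first, only, none or still open, it means among the compounds named here.

Compound 1 `C=C1CC[C@@H]2[C@](C)(CCC[C@]2(C)C(=O)OC)[C@H]1Cc1c(C)cccc1C(=O)OC` was tested in a functional assay on MCF7 cells (Homo sapiens) for cytotoxicity, read by sulforhodamine B assay, with a stated time of 3 days (on this read-out lower numbers stand for stronger inhibition and higher numbers for weaker inhibition), where compound 1 gives 40400 nM, the highest of the two numbers recorded. Compound 2 `C=C1CC[C@@H]2[C@](C)(CCC[C@]2(C)C(=O)OC)[C@H]1Cc1c(C)ccc(C(=O)OC)c1C(=O)OC` gives 33000 nM, and the step of a 1.2-fold lower number from compound 1 to compound 2 (0.09 log units; within the scatter) lies within the scatter. Compound 3 `C=C1CC[C@@H]2[C@](C)(CCC[C@]2(C)C(=O)OC)[C@H]1Cc1c(C)cccc1C#N` differs from compound 1 by cyano in place of methoxycarbonyl on an aromatic carbon. Going by the values given here, no measured step touches this exact position, and the one step known was within the scatter, so little change is expected in this assay. Compound 3 is therefore estimated at 35000 nM, between 12000 nM and 100000 nM, corresponding to an expected step of a 1.2-fold lower number from compound 1 to compound 3 (0.06 log units; within the scatter).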

Compound 3, half-maximal inhibitory concentration: 39600 nM
Compound 3: middle estimate off by 1.1-fold (0.05 log units), on the low side; the range from low to high includes it.
By their numbers in this assay, from the lowest: compounds 2, 3 and 1 (each within the scatter of the next).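

Putting cyano in place of methoxycarbonyl on this aromatic carbon gives a 1.0-fold lower number from compound 1 to compound 3 (0.01 log units; within the scatter) in this assay. The entering group has 2 heavy atoms against 4 for the leaving one, and 1 hydrogen-bond acceptor against 2, yet this read-out does not separate the two groups. No measurement here explains why they read alike. Going by these compounds, whether an amine or a carboxylic acid on this carbon would shift the number beyond the scatter remains open. So does whether any group at this position can do so.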